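Fluoro for methoxy on the hydrazone aryl ring

This account rests on a few compounds, and the source may have more. Where it says the series, first, only, none or still open, it means among the compounds named here.

Compound 1, `Clc1cccc(CSc2nnc(-c3ccncc3)n2-c2ccccc2)c1`, gives 10500 nM in a functional assay on MCF7 cells (Homo sapiens) for inhibition, read by MTT assay, with a stated time of 48 h; a higher number here means a weaker inhibitor, a lower number a stronger inhibitor.
Compound 2, `Fc1ccc(CSc2nnc(-c3ccncc3)n2-c2ccccc2)cc1`, gives 21100 nM in this assay.
Compound 3, `COc1ccc(/C=N/NC(=O)CSc2nnc(-c3ccncc3)n2-c2ccccc2)cc1`, gives 23700 nM in this assay.

Compound 3 has the highest of the three numbers. Its gap to compound 2 is within the scatter, while its gap to compound 1 is beyond it. Compound 4, `O=C(CSc1nnc(-c2ccncc2)n1-c1ccccc1)N/N=C/c1ccc(F)cc1`, differs from compound 3 by fluoro in place of methoxy on an aromatic carbon, that is, 4-methoxyphenyl to 4-fluorophenyl. Going by the values given here, no measured pair shows this exchange. Among the compounds with values here, the only measured step, a 2.0-fold higher number from compound 1 to compound 2 (0.30 log units; within the scatter), concerns a different exchange at a different place, a fluorophenyl entering on a saturated chain carbon bound to a sulfur, and it stayed within the scatter. Nothing in the measured data therefore points to a step beyond the scatter from compound 3 to compound 4, and the estimate is a step of a 1.1-fold lower number from compound 3 to compound 4 (0.03 log units; within the scatter). Compound 4 is expected to give about 22000 nM in this assay, within a range of 9000 nM to 55000 nM.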

Compound 4, half-maximal inhibitory concentration: 12300 nM
Estimate against measurement, compound 4: 1.8-fold (0.25 log units) above; measured number inside the range.
By their numbers in this assay, from the lowest: compounds 1, 4, 2 and 3 (each within the scatter of the next, the first and the last beyond it).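

In this assay, fluoro in place of methoxy on an aromatic carbon, para to a large group, gives a 1.9-fold lower number from compound 3 to compound 4 (0.28 log units; within the scatter). Going by these compounds alone, this is the first measured pair at this position, and it shows that the exchange of 4-methoxyphenyl for 4-fluorophenyl, which removes the hydrogen-bond acceptor of methoxy, leaves the number within the scatter. No measurement shown here bears on why the step has this size.

The compounds shown leave open how an amine, a carboxylic acid or a longer alkoxy chain at this position would read in this assay. They also leave open whether methoxy and fluoro would stay within the scatter of each other on another carbon of the same ring.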